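Swapping the substituted benzyl arm for a pyridylmethyl arm

The compounds below may be only part of what the source reports. "The series", "measured", "known", "first", "only" and "open" are said of these compounds alone.

Measured so far in a functional assay on CEM-CCRF cells for antagonist activity at C-X-C chemokine receptor type 4 (Homo sapiens), read by calcium flux; on this read-out higher numbers stand for weaker inhibition and lower numbers for stronger inhibition:
- compound 1, `NCc1cc(F)ccc1CN(Cc1nc2ccccc2[nH]1)C1CCCc2cccnc21`: 219 nM
- compound 2, `COCc1ccc(CN(Cc2nc3ccccc3[nH]2)C2CCCc3cccnc32)c(CN)c1`: 21 nM

Within the data shown here, compound 2 gives the lowest number of the two in this assay, and the only step among the measured compounds leads to it: a 10-fold lower number from compound 1 to compound 2 (1.02 log units; beyond the scatter). That step touches only one substituent on the aromatic ring of the benzyl arm, and it shows that this position is sensitive.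

Compound 3, `NCc1ccncc1CN(Cc1nc2ccccc2[nH]1)C1CCCc2cccnc21`, has not been measured yet. It differs from compound 2 in a larger way: a group of 8 heavy atoms (6 carbon, 2 nitrogen; one six-membered aromatic ring with 1 hetero atom) in place of a group of 11 heavy atoms (9 carbon, 1 nitrogen, 1 oxygen; one six-membered aromatic ring of carbon only), on a saturated chain carbon bound to an amine nitrogen. The methoxymethyl that distinguished compound 2 from compound 1 is gone, and the aromatic ring itself is changed. Among the measured compounds shown here, no measured step covers a ring exchange of this kind, so the only guide is the loss of the methoxymethyl, which in the step from compound 1 to compound 2 was worth a large improvement. Removing it, together with the ring change, is therefore expected to give a weaker compound, with the direction fairly clear but the size uncertain. The expected step in this assay is estimated as a 7.1-fold higher number from compound 2 to compound 3 (0.85 log units; beyond the scatter). Compound 3 is estimated at 150 nM, with a range of 40 nM to 600 nM.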

Compound 3, half-maximal inhibitory concentration: 160 nM
Estimate against measurement, compound 3: 1.1-fold (0.03 log units) below; low and high end bracket the measured number.
By their numbers in this assay, from the lowest: compound 2; then compounds 3 and 1 (each within the scatter of the next).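

In this assay, the change of the whole arm gives a 7.6-fold higher number from compound 2 to compound 3 (0.88 log units; beyond the scatter), so the gain seen with the methoxymethyl on the ring of carbon only does not carry over to the bare ring with 1 hetero atom. Among these compounds, the other new comparison gives a 1.4-fold lower number from compound 1 to compound 3 (0.14 log units; within the scatter), which means that the ring with 1 hetero atom and the fluorine-bearing ring of carbon only cannot be told apart in this assay, and compound 2 remains the one compound whose number clearly stands apart from the others. No supporting measurement accompanies these numbers, so the reason for this pattern stays unknown.

The step to compound 3 changes the ring and removes the methoxymethyl at once, so the compounds shown leave open how much of the loss belongs to each change, a question that the methoxymethyl group carried on the ring with 1 hetero atom would address. They also leave open whether the methoxymethyl itself matters or whether a related group, such as hydroxymethyl or ethoxymethyl, would serve equally well on the ring of carbon only.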